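Swapping the lactam bicycle for a benzodioxin on the ether

This account rests on a few compounds, and the source may have more. Where it says the series, first, only, none or still open, it means among the compounds named here.

Compound 1 `CN(C)c1ccc(C(=O)Nc2cccc(NC(=O)COc3ccc4c(c3)CCC(=O)N4)c2)cc1` carries a bicyclic lactam on the ether oxygen of the shared core. In an assay on isolated protein for inhibition of Rho-associated protein kinase 1 (Homo sapiens), read by scintillation counting, radiometric assay and 33P incorporation, with a stated time of 40 min, in the presence of a further agent that is not named here (a higher number here means a weaker inhibitor, a lower number a stronger inhibitor), compound 1 gives > 10000 nM, which is a limit of the assay rather than a measured number (the limit of > 10000 nM in this assay, at which 1 of the 3 values shown sits). Two measured compounds replace that bicycle with a fluorinated phenyl ring. In this assay compound 2 `COc1ccc(OCC(=O)Nc2cccc(NC(=O)c3ccc(N(C)C)cc3)c2)cc1F` gives 1820 nM. Compound 3 `CC(=O)c1ccc(OCC(=O)Nc2cccc(NC(=O)c3ccc(N(C)C)cc3)c2)cc1F` gives 445 nM. Both exchanges point the same way: an at least 5.4-fold lower number from compound 1 to compound 2 (0.73 log units; beyond the scatter) and an at least 22-fold lower number from compound 1 to compound 3 (1.35 log units; beyond the scatter), while a 4.1-fold lower number from compound 2 to compound 3 (0.61 log units; beyond the scatter) separates the two phenyl variants from each other.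

Compound 4 `CN(C)c1ccc(C(=O)Nc2cccc(NC(=O)COc3ccc4c(c3)OCCO4)c2)cc1` makes a related exchange: a group of 10 heavy atoms (8 carbon, 2 oxygen; one six-membered non-aromatic ring with 2 hetero atoms, one six-membered aromatic ring of carbon only) in place of a group of 11 heavy atoms (9 carbon, 1 nitrogen, 1 oxygen; one six-membered non-aromatic ring with 1 hetero atom, one six-membered aromatic ring of carbon only), on an oxygen on a saturated carbon. As in compounds 2 and 3, the lactam bicycle leaves, but the entering 2,3-dihydro-1,4-benzodioxin-6-yl brings two ether oxygens and no donor, which places it nearer to the methoxy variant of compound 2 than to the acetyl variant of compound 3. Among the measured compounds shown here, the step from compound 1 to compound 2 is therefore the one taken as the guide, and the expected step is an at least 4.0-fold lower number from compound 1 to compound 4 (0.60 log units; beyond the scatter). Since compound 1 stands only at a limit, this is a lower bound on the improvement. Compound 4 is accordingly estimated at 2500 nM, with a range from 700 nM to 10000 nM.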

Compound 4, half-maximal inhibitory concentration: > 10000 nM
Compound 4 was reported as a limit; the forecaster's own chance of this, stated with the estimate: 30%; middle value at least 4.0-fold (0.60 log units) from the limit.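

The loss of the lactam bicycle is not enough on its own, as compound 4 stands at a limit of the assay in this assay, the same place as compound 1: the limit of > 10000 nM in this assay, at which 2 of the 4 values shown sit. The step between these two bicyclic groups cannot be read, so the earlier gain on this oxygen belongs to the two fluorinated phenyl groups and does not extend to the 2,3-dihydro-1,4-benzodioxin-6-yl. Both phenyl groups are clearly separated from it, with an at least 5.4-fold higher number from compound 2 to compound 4 (0.73 log units; beyond the scatter) and an at least 22-fold higher number from compound 3 to compound 4 (1.35 log units; beyond the scatter), so among the four compounds shown, both bicyclic groups sit at the limit and both fluorinated phenyl groups give measured numbers.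

The compounds shown leave open whether the fluorine or the absence of a second ring separates compound 2 from compound 4, and a plain 3-fluorophenyl group would bear on that. They also leave open how a phenyl group carrying an amine or a carboxylic acid would fare on this oxygen, and how far past the limit compound 1 and compound 4 actually lie.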